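Removing the methoxy from compound 1

The source may report more compounds than this note shows. Statements on the series, on what has been measured and on what is new or still open speak of the compounds shown alone.

In a functional assay on A549 cells (Homo sapiens) for antiproliferative activity, read by MTT assay, with a stated time of 48 h (a higher number here means a weaker inhibitor, a lower number a stronger inhibitor), compound 1 `COc1ccc(/C=C/C(=O)Nc2nnc(-c3ccc(C)cc3)s2)cc1` gives 0.66 ug/mL and compound 2 `COc1ccc(/C=C/C(=O)Nc2nnc(-c3ccccc3)s2)cc1` gives 0.76 ug/mL, which lie within the scatter of each other. Compound 3 `O=C(/C=C/c1ccc(F)cc1)Nc1nnc(-c2ccc(Br)cc2)s1` gives 2.83 ug/mL, a clearly higher number than either. Compound 4 `Cc1ccc(-c2nnc(NC(=O)/C=C/c3ccccc3)s2)cc1` changes compound 1 by hydrogen in place of methoxy on an aromatic carbon, para to a large group. Among the measured compounds shown here, no measured step removes this methoxy alone. The closest is a 1.2-fold higher number from compound 1 to compound 2 (0.06 log units; within the scatter), which replaces methyl with hydrogen at a different place. Compound 3 also lacks the methoxy but differs in other ways, so it offers only a weak hint of a higher number. A small rise within the scatter is expected, a 1.7-fold higher number from compound 1 to compound 4 (0.22 log units; within the scatter). Compound 4 is estimated at 1.1 ug/mL, with an expected range of 0.45 ug/mL to 2.8 ug/mL.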

Compound 4, half-maximal inhibitory concentration: 1.38 ug/mL
Beside the measured number, compound 4's estimate is 1.3-fold (0.10 log units) below it; low and high end bracket the measured number.
By their numbers in this assay, from the lowest: compounds 1, 2 and 4 (each within the scatter of the next, the first and the last beyond it); then compound 3.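

In this assay, among the compounds shown here, removing the methoxy gives a 2.1-fold higher number from compound 1 to compound 4 (0.32 log units; beyond the scatter) as a modest step, the first direct reading of the 4-methoxyphenyl to phenyl change at this position, para to a large group. Unlike a 1.2-fold higher number from compound 1 to compound 2 (0.06 log units; within the scatter) at the other end of the molecule, this single-place step lies beyond the scatter. Nothing on hand accounts for the step.

Going by these compounds, whether an amine, a hydroxyl or a longer alkoxy chain at this position would match the methoxy remains open. Also open, on these data alone, is whether removing the methoxy has the same size without the methyl of compound 1.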